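The source may hold more compounds than are shown below. What is called first, only, known or untested is meant among the compounds shown, and "the series" means these compounds.

The measured compounds in this study:

compound 1, `Cc1ccccc1Oc1ccc(C#N)cc1S(=O)(=O)NC(=O)NC(C)C`: 6130 nM
compound 2, `Cc1ccccc1Oc1ccc(C#N)cc1S(=O)(=O)NC(=O)NC(C)(C)C`: 1470 nM
compound 3, `CCCCCNC(=O)NS(=O)(=O)c1cc(C#N)ccc1Oc1ccccc1C`: 1780 nM

In a functional assay on HEK293 cells for antagonist activity at thromboxane A2 receptor (Homo sapiens), read by fluorescence and calcium flux (on this read-out lower numbers stand for stronger inhibition and higher numbers for weaker inhibition), compound 1 gives 6130 nM, the highest of the three numbers. Its nearest neighbour is compound 3, reached by a 3.4-fold lower number from compound 1 to compound 3 (0.54 log units; beyond the scatter); the furthest is compound 2, reached by a 4.2-fold lower number from compound 1 to compound 2 (0.62 log units; beyond the scatter). Between the other two the difference is small: a 1.2-fold higher number from compound 2 to compound 3 (0.08 log units; within the scatter).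

Compound 4, `Cc1cccc(Oc2ccc(C#N)cc2S(=O)(=O)NC(=O)NC(C)C)c1`, has not yet been measured. It differs from compound 1 in one place: 3-methylphenyl in place of 2-methylphenyl on an oxygen on an aromatic ring. The three measured steps all concern the group on the amide-type nitrogen, exchanging isopropyl, tert-butyl and pentyl; none of them alters the 2-methylphenyl on the aromatic oxygen. Going by the values given here, no measured step therefore bears directly on the change from compound 1 to compound 4, and the shared core with its aryl ether is held constant throughout the measured set. With nothing to indicate a direction, the expectation for compound 4 is a number close to that of compound 1, with no step beyond the scatter, but with a wide range to reflect the absence of any comparable step. The estimate for compound 4 in this assay is 6000 nM, with a range from 2000 nM to 18000 nM. This estimate corresponds to an expected step of a 1.0-fold lower number from compound 1 to compound 4 (0.01 log units; within the scatter).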

Compound 4, half-maximal inhibitory concentration: 1690 nM
Compound 4: middle estimate off by 3.6-fold (0.55 log units), on the high side; measured number below the stated range.
By their numbers in this assay, from the lowest: compounds 2, 4 and 3 (each within the scatter of the next); then compound 1.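

Going by these compounds alone, the aryl ether position, held constant in the earlier compounds, turns out to matter in this assay: 3-methylphenyl in place of 2-methylphenyl on the oxygen gives a step beyond the scatter (a 3.6-fold lower number from compound 1 to compound 4 (0.56 log units; beyond the scatter)). The groups that leave and enter have the same heavy atoms and the same counts, so a change in how the methyl-bearing phenyl group is joined is enough to move the number, with no atom gained or lost. The step is modest, as are the two earlier steps from isopropyl on the amide-type nitrogen (a 4.2-fold lower number from compound 1 to compound 2 (0.62 log units; beyond the scatter); a 3.4-fold lower number from compound 1 to compound 3 (0.54 log units; beyond the scatter)), so this compound series now has two places that respond, though nothing available accounts for the effect of this change.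

The compounds shown leave open whether 3-methylphenyl would give a similar step with tert-butyl or pentyl on the amide-type nitrogen, since it appears here only with isopropyl. They also leave open what a chlorine atom or a methoxy group in place of the methyl of the 3-methylphenyl would do to the number at this position.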